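Trading amino for methoxy on the shared core

The compounds below may be only part of what the source reports. "The series", "measured", "known", "first", "only" and "open" are said of these compounds alone.

For the measured compounds named here, in a functional assay on WIL2 cells (Homo sapiens) for inhibition (a lower number here means a stronger inhibitor, a higher number a weaker inhibitor), compound 2 (`Nc1ncnc2c(N[C@@H]3O[C@H](CO)[C@@H](O)[C@H]3O)ncnc12`) gives 0.2 uM and stands at the low end of the three numbers so far, together with compound 3 (`Nc1ncnc2c(N[C@H]3O[C@H](CO)[C@@H](O)[C@H]3O)ncnc12`) at 0.25 uM and well under compound 1 (`COc1ncnc2c(N[C@H]3O[C@H](CO)[C@@H](O)[C@H]3O)ncnc12`) at 2.5 uM on the same scale.

Compound 4 (`COc1ncnc2c(N[C@@H]3O[C@H](CO)[C@@H](O)[C@H]3O)ncnc12`) keeps the configuration of compound 2 and carries methoxy in place of amino on an aromatic carbon.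

Going by the values given here, two measured steps bear on this change. Among the compounds with values here, the same exchange, read in the opposite direction, appears as a 10-fold lower number from compound 1 to compound 3 (1.00 log units; beyond the scatter) and is the closest precedent. The other step is a 1.3-fold higher number from compound 2 to compound 3 (0.10 log units; within the scatter) and comes with the fact that compounds 2 and 3 differ only in the configuration as drawn so the drawn configuration has not moved the number beyond the scatter in the amino pair.

A step of similar size toward a higher number is therefore expected in this assay and is estimated as an 11-fold higher number from compound 2 to compound 4 (1.04 log units; beyond the scatter) in this case. The expected value for compound 4 is 2.2 uM with an estimated range of 0.8 uM to 6 uM for the measurement to come.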

Compound 4, concentration for 50% inhibition: 0.06 uM
For compound 4 the middle estimate is 37-fold (1.56 log units) above the measured one; measured number below the stated range.
By their numbers in this assay, from the lowest: compound 4; then compounds 2 and 3 (each within the scatter of the next); then compound 1.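

The exchange of amino for methoxy on this aromatic carbon has no single direction: with the configuration of compound 2 held, it gives a 3.3-fold lower number from compound 2 to compound 4 (0.52 log units; beyond the scatter), opposite in direction to the step seen in the other configuration, and the two readings do not agree: the same change on two cores in this assay, a 10-fold lower number (1.00 log units; beyond the scatter) from compound 1 to compound 3 and a 3.3-fold higher number (0.52 log units; beyond the scatter) from compound 4 to compound 2, 33-fold (1.52 log units) apart, beyond the scatter of two such steps. The drawn configuration, which left compound 2 and compound 3 within the scatter, is enough on its own to give a 42-fold lower number from compound 1 to compound 4 (1.62 log units; beyond the scatter) in the methoxy pair: the fact that compounds 1 and 4 differ only in the configuration as drawn. The effects of the group and of the configuration at this position therefore cannot be read apart in these four compounds.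

The compounds shown leave open whether other groups at this position, such as ethoxy, methylamino or chlorine, would also depend on the configuration. Nor do they show what underlies the reversal.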